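Furan to ethylpyrrolidine on the shared core

This account rests on a few compounds, and the source may have more. Where it says the series, first, only, none or still open, it means among the compounds named here.

Compound 2 `Cc1cc(NCc2ccco2)n2nc(C)c(-c3ccccc3)c2n1` is one of two measured members of a shared core, the other being compound 1 `Cc1cc(Nc2ccccn2)n2nc(C)c(-c3ccccc3)c2n1`. In a physicochemical assay for solubility, read by HPLC, using the shake flask method, measured as kinetic solubility, with a stated time of 2 h, at pH 7.4 (a lower number here means a less soluble compound, a higher number a more soluble compound), compound 1 gives only a limit of the assay, < 5000 nM. In this assay compound 2 likewise gives only a limit of the assay, < 5000 nM. Among the compounds with values here, the single measured step, a step that the two limits leave unreadable from compound 1 to compound 2, is therefore of a size that cannot be read, and compound 2 stands at the limit of < 5000 nM in this assay, at which 2 of the 2 values shown sit. Compound 3 `CCN1CCCC1CNc1cc(C)nc2c(-c3ccccc3)c(C)nn12` differs from compound 2 by 1-ethylpyrrolidin-2-yl in place of furan-2-yl on a saturated chain carbon bound to a nitrogen on an aromatic ring. Within the data shown here, no measured step bears on this change with a readable size, since both values so far are limits, so the data alone do not fix a direction or a size beyond the scatter in this assay. Compound 3 is nevertheless expected to sit at 20000 nM, within 3000 nM to 150000 nM, which would mean an expected step of an at least 4.0-fold higher number from compound 2 to compound 3 (0.60 log units; beyond the scatter) away from the limit.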

Compound 3, solubility: 172000 nM
Beside the measured number, compound 3's estimate is 8.6-fold (0.93 log units) below it, outside the stated range (above it).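

Within the data shown here, putting 1-ethylpyrrolidin-2-yl in place of furan-2-yl on a saturated chain carbon bound to a nitrogen on an aromatic ring gives the first readable step at this position in this assay: an at least 34-fold higher number from compound 2 to compound 3 (1.53 log units; beyond the scatter). The (1-ethylpyrrolidin-2-yl)methyl group in place of pyridin-2-yl gives a step of the same reading, an at least 34-fold higher number from compound 1 to compound 3 (1.53 log units; beyond the scatter). Both sizes are only minimum sizes because each starting compound rests on a limit of the assay, not a number: the limit of < 5000 nM in this assay, at which 2 of the 3 values shown sit.

The compounds shown do not tell whether the step goes with the ring nitrogen of the 1-ethylpyrrolidin-2-yl group, with its ethyl or with the non-aromatic ring itself. A pyrrolidin-2-yl group without the ethyl, an open-chain diethylamino group or a morpholine at this place would separate these readings.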